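Swapping a Ring Amine for a Methoxyethoxy Chain

A few compounds are considered here, and "the series" means these few. Any claim that something is new, unique, unknown or untested is made for them only; others in the source may bear on it.

Three compounds sharing one core have been examined. Compound 1 `CC(C)CSc1nc(N)nc2c1ncn2/C=C1/CC1(CO)CO` returned "not determined" (no result reported) in an ADME assay on MOLT-3 cells (Homo sapiens) for cytotoxicity, with a stated time of 7 days (a lower number here means that less compound is tolerated, a higher number that more compound is tolerated), and compound 2 `CC(C)CNc1nc(N)nc2c1ncn2/C=C1/CC1(CO)CO` likewise gave "not determined" (no result reported). Compound 3 `Nc1nc(NC2CCCC2)c2ncn(/C=C3/CC3(CO)CO)c2n1` gave > 20000 nM, which is a limit of this assay rather than a number, as recorded in the limit of > 20000 nM in this assay, at which 1 of the 3 values shown sits. For the measured compounds named here, compound 3 thus stands at the limit of this assay among the values shown, with no measured step to any other compound. Compound 4 `COCCOc1nc(N)nc2c1ncn2/C=C1/CC1(CO)CO` carries 2-methoxyethoxy in place of cyclopentylamino on an aromatic carbon. Going by the values given here, no measured step exists to guide the size of this change, so no shift beyond the scatter is expected, and the expected step is a step that the limit leaves unreadable from compound 3 to compound 4. Compound 4 is therefore expected to give about 30000 nM, within 10000 nM to 100000 nM.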

Compound 4, half-maximal cytotoxic concentration: > 20000 nM
Compound 4 ended at the assay's limit (the forecaster's own chance of this, stated with the estimate: 80%); the middle value lies beyond the limit too.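

For the compounds shown here, no step from compound 3 to compound 4 can be read, since both compounds end at a limit rather than at a number: the limit of > 20000 nM in this assay, at which 2 of the 4 values shown sit. On these data alone, whether 2-methoxyethoxy in place of cyclopentylamino changes the tolerated concentration in this assay at all stays open.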